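The source may report more compounds than this note shows. Statements on the series, on what has been measured and on what is new or still open speak of the compounds shown alone.

Of the compounds shown here, two have been measured in a physicochemical assay for solubility, read by HPLC, in phosphate buffer, measured as kinetic solubility, at pH 7.4; a lower number here means a less soluble compound, a higher number a more soluble compound. Compound 1 `CCC(=O)c1cc(-c2ccc(F)cc2)n(-c2ccc(S(N)(=O)=O)cc2)n1` gives 88900 nM in this assay. Compound 2 `CCCC(=O)c1cc(-c2ccc(S(N)(=O)=O)cc2)n(-c2ccc(Cl)cc2)n1` gives 25800 nM in this assay, the lower of the two numbers, and its gap to compound 1 lies beyond the scatter. Compound 3 `NS(=O)(=O)c1ccc(-c2cc(C(=O)N3CCCCC3)nn2-c2ccc(Cl)cc2)cc1` is not yet measured; it differs from compound 2 by piperidin-1-yl in place of propyl on a carbonyl carbon. For the measured compounds named here, no measured pair carries this change, so no reference step exists for it. The expected step is a 1.4-fold lower number from compound 2 to compound 3 (0.16 log units; within the scatter), a small move downward that need not clear the scatter. Compound 3 is estimated at 18000 nM in this assay, within a range from 6000 nM to 50000 nM.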

Compound 3, solubility: 65900 nM
Estimate against measurement, compound 3: 3.7-fold (0.56 log units) below; measured number outside the range, above it.
By their numbers in this assay, from the lowest: compound 2; then compounds 3 and 1 (each within the scatter of the next).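

In this assay, for the compounds shown here, the change from propyl to piperidin-1-yl on a carbonyl carbon gives a 2.6-fold higher number from compound 2 to compound 3 (0.41 log units; beyond the scatter) and is the first step that can be read at this position. This place therefore takes a six-membered non-aromatic ring with the number moving up, modestly, rather than down.

On these data alone, whether the step follows the ring or the nitrogen on the carbonyl carbon stays open, and a diethylamino group or a longer chain at this place would separate the two. No measurement shown gives a reason for the step.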